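Shifting the Chlorine on the Phenyl Group of Compound 1

This account rests on a few compounds, and the source may have more. Where it says the series, first, only, none or still open, it means among the compounds named here.

Measured in a functional assay (aorta) with Rattus norvegicus as the target; on this read-out lower numbers stand for stronger inhibition and higher numbers for weaker inhibition:
- compound 1 `CC1(C)Oc2ccc(C#N)cc2[C@@H](/N=C(\NC#N)Nc2ccc(Cl)cc2)[C@@H]1O`: 1800 nM
- compound 2 `COC(=O)c1cc2ccccc2n1[C@@H]1c2cc(C#N)ccc2OC(C)(C)[C@H]1O`: 33100 nM

Of these two compounds, compound 1 has the lower number in this assay, and the gap to compound 2 lies well beyond the scatter. The next compound to be tested is compound 3 `CC1(C)Oc2ccc(C#N)cc2[C@@H](/N=C(\NC#N)Nc2cccc(Cl)c2)[C@@H]1O`. It differs from compound 1 in one place, with 3-chlorophenyl in place of 4-chlorophenyl on an amine nitrogen. The rest of the structure stays the same.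

For the measured compounds named here, no pair of measured compounds shows what this kind of change does, so the data offer no direct precedent. Compound 2, at 33100 nM, holds no chlorophenyl group and gives little guidance on the swap. The expectation therefore rests on compound 1, at 1800 nM, since compound 3 has the same atoms joined differently. No step beyond the scatter is expected, though a slightly higher number seems the likelier direction. The expected step is a 1.4-fold higher number from compound 1 to compound 3 (0.14 log units; within the scatter). For compound 3 the estimated value is 2500 nM, with an expected range of 800 nM to 8000 nM.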

Compound 3, half-maximal inhibitory concentration: 600 nM
Beside the measured number, compound 3's estimate is 4.2-fold (0.62 log units) above it, outside the stated range (below it).
By their numbers in this assay, from the lowest: compound 3; then compound 1; then compound 2.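

With 3-chlorophenyl in place of 4-chlorophenyl on an amine nitrogen, this assay records a 3.0-fold lower number from compound 1 to compound 3 (0.48 log units; beyond the scatter), a step beyond the scatter. For the compounds shown here, this is the first step that can be read at this position, and it shows that the read-out depends on where the chlorine sits on the phenyl ring, even though the two compounds have the same atoms and the rest of the structure stays the same. The step is modest, and nothing shown gives a measured reason for it, so the result stands as an observation about this one pair.

What the compounds shown leave open is whether the chlorine itself matters at all, since a plain phenyl group, or a bromine or a methoxy group in place of the chlorine, would separate the effect of the atom from the effect of its placement. They also leave open whether the same swap would give a step of similar direction and size on any core other than that of compound 1, as this single pair in one assay cannot say.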